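Both Chlorines Together: Expecting Another Assay Limit

The source may report more compounds than this note shows. Statements on the series, on what has been measured and on what is new or still open speak of the compounds shown alone.

Of the compounds shown here, three sharing one core have been tested in a functional assay on Bel-7402 cells (Homo sapiens) for cytotoxicity, read by MTT assay; a higher number here means a weaker inhibitor, a lower number a stronger inhibitor. Compound 1 `Cc1nc(Nc2ccc(Cl)cc2)sc1C(=O)/C=C/c1ccccc1` gives only a limit of the assay rather than a number, > 25000 nM. Compound 2 `Cc1nc(Nc2ccccc2)sc1C(=O)/C=C/c1ccc(Cl)cc1` likewise gives only a limit, > 25000 nM. Compound 3 `Cc1ccccc1Nc1nc(C)c(C(=O)/C=C/c2ccc(Cl)cc2)s1` also reaches only a limit, > 25000 nM. Compound 3 therefore stands nowhere distinct among the measured compounds: all three values sit at the same limit (the limit of > 25000 nM in this assay, at which 3 of the 3 values shown sit), so no order among them can be read. Within the data shown here, the single measured step that changes one place, a step that the two limits leave unreadable from compound 2 to compound 3, is for that reason of unreadable size.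

Compound 4 `Cc1nc(Nc2ccc(Cl)cc2)sc1C(=O)/C=C/c1ccc(Cl)cc1` is not yet measured. It differs from compound 3 by 4-chlorophenyl in place of 2-methylphenyl on a nitrogen on an aromatic ring. Among the measured compounds shown here, no measured step bears directly on this change, and the one measured step is itself unreadable. The chlorophenyl on the nitrogen is already present in compound 1, which sits at the limit, and the chlorine on the far ring is present in compound 2 and compound 3, both at the limit. Nothing in the measured values points to a readable gain. Compound 4 is therefore expected to sit at or near the limit as well, and the step that the limit leaves unreadable from compound 3 to compound 4 is expected to be unreadable. The estimate for compound 4 in this assay is 35000 nM, between 10000 nM and 120000 nM.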

Compound 4, half-maximal inhibitory concentration: > 25000 nM
Compound 4: only a limit was reported; the forecaster's own chance of this, stated with the estimate: 85%; the middle value is on the limit's open side.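

Compound 4 also reaches only a limit of the assay, so its steps from compound 1, compound 2 and compound 3 cannot be read: the limit of > 25000 nM in this assay, at which 4 of the 4 values shown sit.

The compounds shown leave open how strongly any of the four acts in this assay, and whether any change among them alters that.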